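Extending and branching the acid chain of compound 1

The source may report more compounds than this note shows. Statements on the series, on what has been measured and on what is new or still open speak of the compounds shown alone.

Measured so far:
compound 1, `O=C(O)CCCOc1cc(-c2ccccc2)cc(-c2ccccc2)n1`: 300 nM
compound 2, `COc1ccc(-c2cc(-c3ccccc3)cc(OCCCCCC(=O)O)n2)cc1`: 1000 nM

In an assay on cell membranes from spleen (Cavia porcellus) for binding affinity to leukotriene B4 receptor 1 (Homo sapiens) (a higher number here means a weaker inhibitor, a lower number a stronger inhibitor), compound 1 gives 300 nM, the lower of the two numbers; compound 2 gives 1000 nM, a gap beyond the scatter, but the two compounds differ in more than one place, so no single change can be read from that pair. Compound 3, `CC(CCCCOc1cc(-c2ccccc2)cc(-c2ccccc2)n1)C(=O)O`, differs from compound 1 by a single change: 2-carboxypropyl in place of carboxy on a saturated chain carbon, three bonds along the chain from an oxygen on an aromatic ring. Among the measured compounds shown here, with no measured step of the same kind, the expectation for compound 3 is a modest weakening, a 2.0-fold higher number from compound 1 to compound 3 (0.30 log units; within the scatter), with wide uncertainty. Compound 3 is therefore estimated at 600 nM in this assay, within 150 nM to 2500 nM.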

Compound 3, half-maximal inhibitory concentration: 4 nM
Estimate against measurement, compound 3: 150-fold (2.18 log units) above, outside the stated range (below it).
By their numbers in this assay, from the lowest: compound 3; then compound 1; then compound 2.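

In this assay the swap from carboxy to 2-carboxypropyl on this saturated chain carbon gives a 75-fold lower number from compound 1 to compound 3 (1.88 log units; beyond the scatter) and counts as a large step. The acid end of the chain is therefore far from indifferent, and a change here alone can gain a great deal on the core of compound 1. No available evidence accounts for this gain.

The change lengthens the chain and adds a branch at once, so the compounds shown do not separate the two. An unbranched chain of the same length on the core of compound 1, or an ethyl branch in place of the methyl, would help tell them apart.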